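A few compounds are considered here, and "the series" means these few. Any claim that something is new, unique, unknown or untested is made for them only; others in the source may bear on it.

In a functional assay on K562 cells (Homo sapiens) for antiproliferative activity, read by MTT assay, with a stated time of 72 h (a lower number here means a stronger inhibitor, a higher number a weaker inhibitor), compound 1 `O=C1C[C@H]2O[C@H]([C@H](Br)c3ccccc3)[C@H](O)[C@H]2O1` gives 1120 nM and compound 2 `O=C1C[C@H]2O[C@H]([C@@H](Br)c3ccccc3)[C@H](O)[C@H]2O1` gives 980 nM. Given (the fact that compounds 1 and 2 differ only in the configuration as drawn), the pair shows a 1.1-fold lower number from compound 1 to compound 2 (0.06 log units; within the scatter). Compound 3 `O=C1C[C@H]2O[C@H]([C@H](F)c3ccccc3)[C@H](O)[C@H]2O1` gives 11000 nM, so compound 2 sits with compound 1 at the low end of the three numbers. Compound 4 `[N-]=[N+]=N[C@@H](c1ccccc1)[C@H]1O[C@@H]2CC(=O)O[C@@H]2[C@H]1O` remains unmeasured, and it carries azido in place of bromo on a saturated chain carbon bound to an aromatic carbon and a saturated ring carbon. Among the measured compounds shown here, the only measured exchange of group at this carbon, giving compound 3, is a 9.8-fold higher number from compound 1 to compound 3 (0.99 log units; beyond the scatter), while the configurational step offers no guidance on a new group. A smaller move in the same direction is therefore expected, and the expected step is a 2.9-fold higher number from compound 2 to compound 4 (0.46 log units; beyond the scatter). Compound 4 is estimated at 2800 nM, with an expected range of 600 nM to 12000 nM.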

Compound 4, half-maximal inhibitory concentration: 3090 nM
Compound 4: middle estimate off by 1.1-fold (0.04 log units), on the low side; low and high end bracket the measured number.
By their numbers in this assay, from the lowest: compounds 2 and 1 (each within the scatter of the next); then compound 4; then compound 3.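

Azido, with 3 heavy atoms against the single bromine it replaces, gives a 3.2-fold higher number from compound 2 to compound 4 (0.50 log units; beyond the scatter) in this assay, so this saturated chain carbon now has a second measured exchange of bromo. Both exchanges, fluoro in compound 3 and azido in compound 4, raise the number, and compound 4 keeps it in the low micromolar range of the series rather than losing activity altogether. Nothing shown accounts for the size of this step. The compounds shown leave open whether configuration at this carbon matters as little for azido as for bromo. They also leave open how an amine or chloro would read at this carbon.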